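The source may hold more compounds than are shown below. What is called first, only, known or untested is meant among the compounds shown, and "the series" means these compounds.

In an ADME assay on HEK293 cells (Homo sapiens) for cytotoxicity, with a stated time of 72 h (on this read-out lower numbers stand for an effect already at smaller amounts and higher numbers for an effect only at larger amounts of compound), compound 1 `COc1ccc(-c2nc3ccccc3o2)cc1NC(=O)c1cc([N+](=O)[O-])ccc1Cl` gives > 25000 nM as a limit of the assay and not a number. Among the measured compounds shown here, compound 2 `O=C(Nc1nc(-c2ccc(Cl)cc2)cs1)c1cc([N+](=O)[O-])ccc1Cl` gives 15000 nM as the only actual number so far. Compound 3 `O=C(Nc1nc(-c2ccc(F)c(F)c2)cs1)c1cc([N+](=O)[O-])ccc1Cl` carries 3,4-difluorophenyl in place of 4-chlorophenyl on an aromatic carbon. For the measured compounds named here, no measured step bears on this change, so nothing beyond the scatter is expected in this assay and the estimated change is no change at the digits printed from compound 2 to compound 3 (within the scatter) without a favoured direction. This expectation rests on compound 2 at 15000 nM as its only anchor. Compound 3 is expected at 15000 nM in a range from 7500 nM to 25000 nM by this estimate.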

Compound 3, half-maximal effective concentration: 8300 nM
For compound 3 the middle estimate is 1.8-fold (0.26 log units) above the measured one, and the stated range covers the measured number.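

In this assay, among the compounds shown here, the first step at this position reads a 1.8-fold lower number from compound 2 to compound 3 (0.26 log units; within the scatter), so on the aromatic carbon next to the ring nitrogen, 3,4-difluorophenyl and 4-chlorophenyl cannot be told apart. The exchange of chlorine for two fluorines on the phenyl ring thus leaves the read-out within its usual scatter. No measurement shown accounts for this step. The compounds shown leave open whether a group of another kind at this position, such as an amine, a carboxylic acid or a longer alkyl chain, would give a step beyond the scatter.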